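A few compounds are considered here, and "the series" means these few. Any claim that something is new, unique, unknown or untested is made for them only; others in the source may bear on it.

The measured compounds:

Compound 1, `Cc1ccc(NC(=O)Nc2ccncc2)c(C)c1`: in a functional assay on the whole organism with Mus musculus as the target, in the maximal electroshock model, with a stated time of 30 min (a lower number here means that less compound is needed, a higher number that more compound is needed for the effect), compound 1 gives > 300 mg/kg.
Compound 2, `O=C(Nc1ccncc1)Nc1c(Cl)cccc1Cl`: in this assay compound 2 gives 100 mg/kg.
Compound 3, `Cc1cc(C)c(NC(=O)Nc2ccncc2)c(Cl)c1`: in this assay compound 3 gives 100 mg/kg.

The value of compound 1 is a limit of the assay, not a number: compound 1 sits at the limit of > 300 mg/kg in this assay, at which 1 of the 3 values shown sits. Compound 3 is compound 1 with one change, (chloro in place of hydrogen on an aromatic carbon), and that change gives an at least 3.0-fold lower number from compound 1 to compound 3 (0.47 log units; beyond the scatter). Compound 2 carries a different core, and the difference between the two cores is not broken down here; in this assay compound 2 stands level with compound 3, within the scatter.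

Compound 4, `O=C(Nc1ccncc1)Nc1c(Cl)cc(Cl)cc1Cl`, is compound 2 with the change (chloro in place of hydrogen on an aromatic carbon). Going by the values given here, this is the same kind of change as the one from compound 1 to compound 3, but the surroundings differ: in compound 3 the new chloro sits ortho to a large group and meta to two methyl groups, whereas in compound 4 it sits meta to two chloro groups and para to a large group. Going by these compounds, because the earlier change gave an at least 3.0-fold lower number from compound 1 to compound 3 (0.47 log units; beyond the scatter), the expected step here is a 1.7-fold lower number from compound 2 to compound 4 (0.22 log units; within the scatter), smaller since the earlier step started from a limit and its full size is unknown. Compound 4 is therefore expected to give 60 mg/kg in this assay, estimated between 25 mg/kg and 150 mg/kg.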

Compound 4, minimum effective dose: 300 mg/kg
Beside the measured number, compound 4's estimate is 5.0-fold (0.70 log units) below it, and the stated range ends below it.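

Chloro in place of hydrogen on an aromatic carbon gives a 3.0-fold higher number from compound 2 to compound 4 (0.48 log units; beyond the scatter), so in this assay more compound is needed for the effect after this change, whereas the earlier step on the other core went the opposite way: the same change on two cores in this assay, an at least 3.0-fold lower number (0.47 log units; beyond the scatter) from compound 1 to compound 3 and a 3.0-fold higher number (0.48 log units; beyond the scatter) from compound 2 to compound 4, at least 9.0-fold (0.95 log units) apart, beyond the scatter of two such steps

Going by these compounds, for compound 1, the starting point of that earlier step, > 300 mg/kg is a limit and not a number, and the full size of the step stays unknown. These two pairs show that this change cannot simply be carried from one core to another in this series, even in its direction, but two pairs make no general rule and do not show whether the difference comes from the rest of the core or from the place the new chloro takes.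

The compounds shown leave open how this ring responds to substituents other than the chloro and methyl groups seen here. A fluoro, a methoxy or a trifluoromethyl group in the place the new chloro takes in compound 4 would help to show whether the higher number belongs to the chloro itself or to any group at that place.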